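The source may hold more compounds than are shown below. What is called first, only, known or untested is meant among the compounds shown, and "the series" means these compounds.

Series notes. The shared core of compound 1 `CC1=C/C(=C\C(C)C)C(=O)C(C)(O)C12CC2` carries an isopropyl on a double-bonded chain carbon bound to a double-bonded ring carbon; compound 2 `C/C=C1\C=C(C)C2(CC2)C(C)(O)C1=O` has a methyl there, compound 3 `CC1=C/C(=C\c2cccs2)C(=O)C(C)(O)C12CC2` a thiophen-2-yl, and compound 4 `CC1=C/C(=C\c2ccccc2)C(=O)C(C)(O)C12CC2` a phenyl, still to be measured. In a functional assay on A-375 cells (Homo sapiens) for antiproliferative activity (a lower number here means a stronger inhibitor, a higher number a weaker inhibitor), compound 1 gives 130 nM. In this assay compound 2 gives 4 nM. For compound 3 this assay reports only a limit, > 10000 nM. Compound 3 thus stands at the weak end of the numbers shown, sitting at the limit of > 10000 nM in this assay, at which 1 of the 3 values shown sits. The measured steps are a 33-fold lower number from compound 1 to compound 2 (1.51 log units; beyond the scatter), an at least 76-fold higher number from compound 1 to compound 3 (1.88 log units; beyond the scatter) and an at least 2500-fold higher number from compound 2 to compound 3 (3.39 log units; beyond the scatter); among these three compounds the larger group at this place went with the higher number in every pair. The change now followed is phenyl in place of thiophen-2-yl on a double-bonded chain carbon bound to a double-bonded ring carbon, one aromatic ring exchanged for another of similar size. Going by the values given here, no measured step compares two aromatic rings at this place; the steps that bear on it, an at least 76-fold higher number from compound 1 to compound 3 (1.88 log units; beyond the scatter) and an at least 2500-fold higher number from compound 2 to compound 3 (3.39 log units; beyond the scatter), show only that an aromatic ring here pushed the number out of the range of the assay. Compound 4 is therefore expected to stay weak, with a step that the limit leaves unreadable from compound 3 to compound 4 expected to be small and within the scatter, and a limit may be reported again. The estimate for compound 4 is 15000 nM, with a range from 3000 nM to 80000 nM.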

Compound 4, half-maximal inhibitory concentration: > 10000 nM
Compound 4: only a limit was reported; the forecaster's own chance of this, stated with the estimate: 65%; the middle value lies beyond the limit too.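

In this assay compound 4 gives > 10000 nM as a limit and not a number. The phenyl group gives an at least 2500-fold higher number from compound 2 to compound 4 (3.39 log units; beyond the scatter) and an at least 76-fold higher number from compound 1 to compound 4 (1.88 log units; beyond the scatter), so the loss on a double-bonded chain carbon bound to a double-bonded ring carbon is not confined to thiophen-2-yl and does not depend on that ring's sulfur or its five-membered size. With two different aromatic rings now giving the same outcome, the series shows a sharp drop from the alkyl groups to both aromatic rings, and compound 3 and compound 4 now both sit at the limit: the limit of > 10000 nM in this assay, at which 2 of the 4 values shown sit.

From the compounds shown here alone, no step can be read between compound 3 and compound 4, and how far either lies past the limit remains unknown, so the two aromatic rings cannot be ranked against each other. Also open, going by these compounds, is where between the alkyl groups and the aromatic rings the activity is lost, and whether a cyclohexyl group, a pyridine ring or a phenyl ring carrying an amine would return a measurable value at this place.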